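From hydroxy to amino on a small side chain

A few compounds are considered here, and "the series" means these few. Any claim that something is new, unique, unknown or untested is made for them only; others in the source may bear on it.

Of the compounds shown here, two have been measured so far in a functional assay on A2780 cells (Homo sapiens) for antiproliferative activity, read by MTT assay, with a stated time of 48 h; on this read-out lower numbers stand for stronger inhibition and higher numbers for weaker inhibition. Compound 1 (`COc1ccc(C(=O)c2ccc(OC)c3c2C=CC(C)(C)O3)c(NC(=O)CBr)c1`) gives 2150 nM in this test. Compound 2 (`C=C(c1ccc(OC)cc1NC(=O)CO)c1ccc(OC)c2c1OC(C)(C)C=C2`) gives 40 nM and holds the lower of the two numbers, which means stronger inhibition, and the gap between them lies well beyond the usual scatter of repeated measurements. These two compounds differ in more than one place, so their gap cannot be tied to any single change.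

Compound 3 (`C=C(c1ccc(OC)cc1NC(=O)CN)c1ccc(OC)c2c1OC(C)(C)C=C2`) departs from compound 2 in just one place (amino in place of hydroxy on a saturated chain carbon bound to a carbonyl carbon), with amino in place of hydroxy on a saturated chain carbon bound to a carbonyl carbon. Within the data shown here, no measured pair shows this swap on its own, so the expectation starts from compound 2 at 40 nM and remains uncertain. In this assay the expected outcome is a small shift towards weaker inhibition, probably none beyond the scatter, and the estimated change is a 1.5-fold higher number from compound 2 to compound 3 (0.18 log units; within the scatter) on this scale. For compound 3 the estimated value is 60 nM with an expected range from 15 nM to 250 nM in this test.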

Compound 3, half-maximal inhibitory concentration: 80 nM
The estimate for compound 3 lay 1.3-fold (0.12 log units) below the measured number; measured number inside the range.
By their numbers in this assay, from the lowest: compounds 2 and 3 (each within the scatter of the next); then compound 1.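

Among these compounds, this is the first comparison that isolates one change: with amino in place of hydroxy on a saturated chain carbon bound to a carbonyl carbon, this assay gives a 2.0-fold higher number from compound 2 to compound 3 (0.30 log units; within the scatter) on this side chain. The pair therefore cannot be told apart in this test, so on this core and in these cells, the hydroxy group is not needed for nanomolar activity and amino can stand in its place. The two groups match in the counts computed for them, and no measurement here accounts for what this swap does or does not do in the cells.

Going by these compounds, two groups on one side chain say little about how much variation this place accepts, and it remains open whether a carboxylic acid, a dimethylamino group or a longer chain such as aminoethyl would keep a number in the same range. The larger gap between compound 1 and the other two compounds also stays unassigned, since compound 1 differs from each of them in more than one place.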